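The source may hold more compounds than are shown below. What is called first, only, known or untested is meant among the compounds shown, and "the series" means these compounds.

Compound 1 `O=C(O)Cc1sc(C(c2ccc(F)cc2)c2ccc(F)cc2)nc1-c1cc(F)cc(F)c1` belongs to a small set of acids built on one shared core. In an in vitro functional assay on HEK285-7 cells for antagonist activity at prostaglandin D2 receptor 2 (Homo sapiens), read by BRET and beta-arrestin recruitment (a lower number here means a stronger inhibitor, a higher number a weaker inhibitor), compound 1 gives 340 nM. Among the numbers recorded, that is the higher of the two; the nearest neighbour, compound 3 `O=C(O)Cc1sc(C(c2ccccc2)c2ccc(F)c(F)c2)nc1-c1ccc(F)cc1`, gives 64 nM in this assay, a lower number whose gap from compound 1 lies beyond the usual scatter of repeated measurements. Compound 2 `O=C(O)Cc1sc(C(c2ccccc2)c2ccccc2)nc1-c1ccc(C(F)(F)F)cc1` is reported in this assay only as a limit, > 100000 nM, and not as a number (the limit of > 100000 nM in this assay, at which 1 of the 3 values shown sits).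

The step from compound 1 to compound 4 `CS(=O)(=O)Nc1cccc(-c2nc(C(c3ccc(F)cc3)c3ccc(F)cc3)sc2CC(=O)O)c1` exchanges one aromatic substituent of the core: 3-(methanesulfonamido)phenyl in place of 3,5-difluorophenyl on an aromatic carbon. The aryl group on the core is therefore changed from a halogenated ring to one carrying a methanesulfonamide, with its hydrogen-bond donor and acceptors, while the carboxymethyl group and the bis(4-fluorophenyl)methyl substituent stay as they are.

For the measured compounds named here, no measured pair isolates this kind of exchange, so the size of the step in this assay can only be guessed. Compound 4 is expected to give roughly 600 nM in this assay, somewhere between 80 nM and 5000 nM. That estimate implies a step of a 1.8-fold higher number from compound 1 to compound 4 (0.25 log units; within the scatter), expected to be small, a modest weakening that may not rise beyond the scatter.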

Compound 4, half-maximal inhibitory concentration: 370 nM
Compound 4: the middle estimate sits 1.6-fold (0.21 log units) above what was measured; the range from low to high includes it.
By their numbers in this assay, from the lowest: compound 3; then compounds 1 and 4 (each within the scatter of the next). At a limit, above all of these: compound 2.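

In this assay, putting 3-(methanesulfonamido)phenyl in place of 3,5-difluorophenyl gives a 1.1-fold higher number from compound 1 to compound 4 (0.04 log units; within the scatter), so the two compounds cannot be told apart. This is the first pair shown that differs in this place alone, on the aromatic carbon next to the ring nitrogen and next to the ring atom that bears the carboxymethyl group, and it shows that a ring without fluorine, carrying a hydrogen-bond donor and acceptors, stands here with no measurable difference from the halogenated ring as long as the bis(4-fluorophenyl)methyl substituent stays in place. Nothing shown gives a reason for this result.

Going by these compounds, it remains open whether the same holds for a simple amine or a carboxylic acid on this aryl ring in place of the methanesulfonamide, or for a longer chain such as an ethanesulfonamide. On these data alone, it is also open whether the exchange would read the same with a different diarylmethyl group on the core, since compounds 2 and 3 differ from compound 1 in more than one place and offer no such comparison.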